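Swapping a Naphthyl Tail for a Chlorinated Benzyl

The source may report more compounds than this note shows. Statements on the series, on what has been measured and on what is new or still open speak of the compounds shown alone.

Of the compounds shown here, three from this series have been tested in a functional assay on HCT-116 cells (Homo sapiens) for cytotoxicity, read by MTT assay, with a stated time of 72 h; on this read-out higher numbers stand for weaker inhibition and lower numbers for stronger inhibition. Compound 1, `Cc1cc(-c2ccccc2)n(/C(N)=N/S(=O)(=O)c2cc(C)c(Cl)cc2SCc2cccc3ccccc23)n1`, carries a (naphthalen-1-yl)methyl group on its sulfur and gives 7000 nM in this assay. Compound 2, `Cc1cc(S(=O)(=O)/N=C(\N)n2nccc2-c2ccccc2)c(SCc2ccccc2C)cc1Cl`, carries a 2-methylbenzyl group instead and gives 16000 nM. Compound 3, `Cc1cc(S(=O)(=O)/N=C(\N)n2nccc2-c2ccccc2)c(SCc2ccc(Cl)cc2)cc1Cl`, carries a 4-chlorobenzyl group and gives 7000 nM. Compound 1 and compound 3 therefore read the same at the digits shown, while compound 2 reads higher than compound 1 by a margin beyond the usual scatter.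

Compound 4, `Cc1cc(-c2ccccc2)n(/C(N)=N/S(=O)(=O)c2cc(C)c(Cl)cc2SCc2ccccc2Cl)n1`, differs from compound 1 in one place: 2-chlorophenyl in place of naphthalen-1-yl on a saturated chain carbon bound to a sulfur. Among the compounds with values here, only one measured step bears directly on this position, namely a 2.3-fold lower number from compound 2 to compound 3 (0.36 log units; beyond the scatter), and it is modest. That step concerns a 2-methylphenyl and a 4-chlorophenyl, while here a naphthalen-1-yl gives way to a 2-chlorophenyl, so the guidance is indirect. Because compound 2, with its 2-methylphenyl, gives 16000 nM while compound 1 gives 7000 nM, a small shift toward a higher number seems the likeliest outcome, though one within or barely beyond the scatter. Compound 4 is thus estimated at 9000 nM, with a range from 4000 nM to 20000 nM, which is expected to amount to a 1.3-fold higher number from compound 1 to compound 4 (0.11 log units; within the scatter).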

Compound 4, half-maximal inhibitory concentration: 170000 nM
Compound 4: the middle estimate sits 19-fold (1.28 log units) below what was measured; the measured number lies above the stated range.
By their numbers in this assay, from the lowest: compounds 1 and 3 (each within the scatter of the next); then compound 2; then compound 4.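

Within the data shown here, the group on the saturated chain carbon bound to a sulfur matters far more in this assay than the earlier compounds suggested: replacing naphthalen-1-yl, with its 2 six-membered aromatic rings and 10 heavy atoms, by 2-chlorophenyl, with one such ring and 7 heavy atoms, gives a 24-fold higher number from compound 1 to compound 4 (1.39 log units; beyond the scatter). Among these compounds, the only earlier change at this position, a 2.3-fold lower number from compound 2 to compound 3 (0.36 log units; beyond the scatter), was modest by comparison and came from a pair that differs from compound 4 in more than one place, so this is the first direct reading at this position on the core of compound 1. No measurement here accounts for the size of this jump.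

Among the compounds shown here, the single step changes the ring count and adds a chlorine together, so it cannot show whether the loss of the second ring, the arrival of the chlorine or the chlorine's location drives the rise. An unsubstituted phenyl on the core of compound 1 would help pull these apart, and a cyclohexyl at the same place would test whether an aromatic ring is needed there at all.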